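The compounds below may be only part of what the source reports. "The series", "measured", "known", "first", "only" and "open" are said of these compounds alone.

In a functional assay on A549 cells (Homo sapiens) for inhibition, read by CCK-8 assay, with a stated time of 72 h, tested at 2 uM (on this read-out lower numbers stand for less inhibition of growth and higher numbers for more inhibition of growth at the one concentration tested), compound 2, `Cc1cc(C)cc(SCc2ccc(/C=C/C(=O)Nc3ccccc3N)cc2)c1`, gives 46.1%. Among the three measured compounds this is the second highest number. Compound 3, `Cc1ccc(SCc2ccc(C(=O)Nc3ccccc3N)cc2)cc1`, gives 40.5%, and the two values lie within the scatter of one another, so nothing can be said about their order. Compound 1, `Nc1ccccc1NC(=O)c1ccc(CSc2nccc(C(F)(F)F)n2)cc1`, gives 75.4%, a number beyond the scatter above that of compound 2; only compound 1 is separated from compound 2 by more than the scatter.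

Compound 4, `Nc1ccccc1NC(=O)/C=C/c1ccc(CSCCc2ccccc2)cc1`, has not yet been measured in this assay. It is built from the same atoms as compound 2, joined differently: phenethyl in place of 3,5-dimethylphenyl on a sulfur. For the measured compounds named here, no step between two measured compounds tells what such an exchange on the sulfur does. None of the three measured compounds differs from another in one place only, so their values give no guide of their own for it.

With nothing to lean on, the expected step of a number 3.1 percentage points lower from compound 2 to compound 4 (within the scatter) is a small one, not beyond the scatter in either direction. Compound 4 is therefore estimated to give 43% in this assay, with a range from 22% to 66% that spans the band in which compound 2 and compound 3 sit and allows for some movement toward the higher number of compound 1.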

Compound 4, percent growth inhibition at one concentration: 45.7%
Compound 4: middle estimate off by 2.7 percentage points, on the low side, and the stated range covers the measured number.
By their numbers in this assay, from the lowest: compounds 3, 4 and 2 (each within the scatter of the next); then compound 1.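

In this assay, for the compounds shown here, the exchange of 3,5-dimethylphenyl for phenethyl gives the first reading at this position, on a sulfur whose other neighbour is a saturated chain carbon, and the step is a number 0.4 percentage points lower from compound 2 to compound 4 (within the scatter), so the change cannot be told apart from repeat scatter. Both groups hold 8 heavy atoms and one six-membered aromatic ring of carbon only, so this pair shows that these two arrangements of the same atoms on the sulfur give growth inhibition that cannot be separated at the one concentration tested. No measurement at hand bears on this result or offers an account of it.

Going by these compounds, what a carboxylic acid, an amine or a longer chain in place of these groups on the sulfur would do remains open, since both groups compared here are carbon-only and share the same counts. Also open, on these data alone, is whether the same exchange would read alike on the core of compound 3, and whether compound 2 and compound 4 would stay inseparable at other concentrations in this assay.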